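The source may hold more compounds than are shown below. What is called first, only, known or untested is meant among the compounds shown, and "the series" means these compounds.

In a functional assay on MCF7 cells (Homo sapiens) for antiproliferative activity, read by sulforhodamine B assay, with a stated time of 48 h, tested at 50 uM (on this read-out higher numbers stand for more inhibition at the one concentration tested (going by the name of the read-out) and lower numbers for less inhibition), the three measured compounds give these numbers:

Compound 1 `Cc1cc2c(C(C)C)ccc(C)c2cc1OC(=O)c1cccc(C(F)(F)F)c1` gives 41.5%.
Compound 2 `CC1=CC[C@H](C(C)C)c2cc(C)c(OC(=O)Nc3ccccc3)cc21` gives 75.1%.
Compound 3 `CC1=CC[C@H](C(C)C)c2cc(C)c(OC(=O)c3ccc([N+](=O)[O-])cc3)cc21` gives 72.9%.

Compound 3 stands second highest of the three in this assay. Its number and that of compound 2 lie within the scatter of each other, so no order between those two can be claimed; compound 1 sits well below both, beyond the scatter.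

Compound 4 `CC1=CC[C@H](C(C)C)c2cc(C)c(OC(=O)c3ccc(Cl)cc3)cc21` is the next compound, and it has not yet been measured in this assay. It differs from compound 3 in one place: chloro in place of nitro on an aromatic carbon.

Among the measured compounds shown here, only one measured step is known, a number 2.2 percentage points lower from compound 2 to compound 3 (within the scatter), and it concerns a change at the carbonyl carbon, not a change of the group on the aromatic ring. For the measured compounds named here, no step with chloro in place of nitro has been measured, so the expectation for compound 4 rests on the thin base that compound 3 gives 72.9% and that the only measured change to the ester side stayed within the scatter. Compound 4 is therefore expected to give about 68% in this assay, with a range from 50% to 84%. This estimate means a step of a number 4.9 percentage points lower from compound 3 to compound 4 (within the scatter), expected to fall within the scatter.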

Compound 4, a percentage reported as inhibition, at one concentration (the size of the read-out at that concentration, not a potency): 79.7%
The estimate for compound 4 lay 11.7 percentage points below the measured number, and the stated range covers the measured number.
By their numbers in this assay, from the lowest: compound 1; then compounds 3, 2 and 4 (each within the scatter of the next).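

In this assay, among the compounds shown here, putting chloro in place of nitro on the aromatic carbon para to a large group gives a number 6.8 percentage points higher from compound 3 to compound 4 (within the scatter) and is the first measured change at this position: a single chlorine atom with no hydrogen-bond acceptors and a nitro group of three heavy atoms with two acceptors cannot be told apart on this read-out. Replacing anilino on the carbonyl carbon with 4-chlorophenyl gives a number 4.6 percentage points higher from compound 2 to compound 4 (within the scatter) and so compound 2, compound 3 and compound 4 form one level group in which no order can be claimed, whichever of these three groups is carried on the carbonyl carbon. No measurement at hand offers a reason why the two groups on the ring read alike.

On these data alone, it remains open whether the number would hold with a very different group at this position, such as an amine, a carboxylic acid or a longer alkyl chain. Because each number comes from a single concentration, the compounds shown also leave open whether compound 3 and compound 4 would still read alike at lower concentrations.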